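The source may report more compounds than this note shows. Statements on the series, on what has been measured and on what is new or still open speak of the compounds shown alone.

Compound 1 `O[C@H](COCCOC[C@@H](O)Cc1c[nH]nn1)Cc1ccc(-c2ccccc2)cc1` and compound 2 `O[C@H](COCCOC[C@@H](O)Cc1cn(Cc2ccc(C(F)(F)F)cc2)nn1)Cc1ccc(-c2ccccc2)cc1` share a core that differs only at one aromatic nitrogen of the five-membered ring. In a functional assay on SGC-7901 cells (Homo sapiens) for inhibition, read by MTT assay, with a stated time of 72 h (a higher number here means a weaker inhibitor of growth, a lower number a stronger inhibitor of growth), compound 1 gives > 100000 nM, which is a limit of the assay rather than a number. In this assay compound 2 gives 8700 nM, the only number shown among the two compounds. Putting 4-(trifluoromethyl)benzyl in place of hydrogen on that aromatic nitrogen gave an at least 11-fold lower number from compound 1 to compound 2 (1.06 log units; beyond the scatter), judged against (the limit of > 100000 nM in this assay, at which 1 of the 2 values shown sits).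

Compound 3 `O[C@H](COCCOC[C@@H](O)Cc1cn(-c2cncc3ccccc23)nn1)Cc1ccc(-c2ccccc2)cc1` keeps the substituted nitrogen but carries a different group: isoquinolin-4-yl in place of 4-(trifluoromethyl)benzyl on an aromatic nitrogen. Among the measured compounds shown here, the one measured step shows only that a group on this nitrogen, rather than hydrogen, brings the number down strongly; no step compares two different groups there. Since compound 3 keeps a group of similar size on the same nitrogen, the change from compound 2 to compound 3 is expected to be a 1.1-fold higher number from compound 2 to compound 3 (0.06 log units; within the scatter), within the scatter in either direction. Compound 3 is therefore estimated at 10000 nM in this assay, with a range from 3000 nM to 40000 nM.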

Compound 3, concentration for 50% growth inhibition: 29300 nM
Compound 3: middle estimate off by 2.9-fold (0.47 log units), on the low side, within the range that was stated.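

In this assay, among the compounds shown here, what sits on this aromatic nitrogen matters, not only whether something sits there: isoquinolin-4-yl in place of 4-(trifluoromethyl)benzyl gave a 3.4-fold higher number from compound 2 to compound 3 (0.53 log units; beyond the scatter), the first comparison of two groups at this position. Isoquinolin-4-yl in place of hydrogen gave an at least 3.4-fold lower number from compound 1 to compound 3 (0.53 log units; beyond the scatter), so both groups shown give a lower number than hydrogen, though compound 3 does not reach compound 2. The true size of each step from compound 1 remains unknown, because each one is judged against a limit, which sets only its smallest possible size: the limit of > 100000 nM in this assay, at which 1 of the 3 values shown sits.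

The step from compound 2 to compound 3 changes several things at once, as three fluorine atoms leave and a second six-membered aromatic ring with one ring nitrogen enters, so the compounds shown do not separate these changes. Going by these compounds, it also remains open how a plain benzyl group, or a benzyl group carrying a carboxylic acid or an amine, would behave on this nitrogen in this assay.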